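The source may report more compounds than this note shows. Statements on the series, on what has been measured and on what is new or still open speak of the compounds shown alone.

Measured in an in vitro ADME assay on microsomes from liver (Homo sapiens) for metabolic stability, read by LC-MS, using NADPH, tested at 1 uM; on this read-out lower numbers stand for a shorter-lived compound and higher numbers for a longer-lived compound:
- Compound 1 `O=C1CN(Cc2ccc(-c3ccc(F)c(CN4CCCCC4)n3)cc2)C(=O)N1CC1CC1`: 0.333 h
- Compound 2 `CCN1C(=O)CN(Cc2ccc(-c3cccc(CN4CCCCC4)n3)cc2)C1=O`: 2 h
- Compound 3 `CC(C)CN1C(=O)CN(Cc2ccc(-c3ccc(F)c(CN4CCCCC4)n3)cc2)C1=O`: 0.217 h

Compound 3, at 0.217 h, cannot be told apart from compound 1 within the scatter, while compound 2, at 2 h, stands clearly higher than both.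

The next structure is compound 4 `CCN1C(=O)CN(Cc2ccc(-c3ccc(F)c(CN4CCCCC4)n3)cc2)C1=O`, reached from compound 3 by methyl in place of isopropyl on a saturated chain carbon bound to an amide-type nitrogen in a ring. In words, this is methyl in place of isopropyl on a saturated chain carbon bound to an amide-type nitrogen in a ring. Cut one bond further out, the same change reads isobutyl to ethyl.

Among the compounds with values here, only one measured step changes this chain while leaving the rest of the molecule alone: a 1.5-fold lower number from compound 1 to compound 3 (0.19 log units; within the scatter). That step is small, so it gives no reason to expect a large move. Compound 2 also carries the ethyl chain but lacks the fluorine of the other compounds, and its 2 h points upward. Its gap to compound 3 mixes two changes, however, so it counts for little here.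

The expected move is modest and upward, a 1.8-fold higher number from compound 3 to compound 4 (0.27 log units; within the scatter). The estimated half-life of compound 4 is 0.4 h, with an expected range of 0.2 h to 1 h.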

Compound 4, half-life in the Homo sapiens assay: 1.45 h
Estimate against measurement, compound 4: 3.6-fold (0.56 log units) below, outside the stated range (above it).
By their numbers in the Homo sapiens assay, from the lowest: compounds 3 and 1 (each within the scatter of the next); then compounds 4 and 2 (each within the scatter of the next).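

Within the data shown here, the size of this chain matters more than the earlier compounds suggested: in the Homo sapiens assay, isobutyl to ethyl gives a 6.7-fold higher number from compound 3 to compound 4 (0.82 log units; beyond the scatter), and the cyclopropyl to methyl change at the same place gives a 4.4-fold higher number from compound 1 to compound 4 (0.64 log units; beyond the scatter), so the ethyl chain separates compound 4, at 1.45 h, from both compounds with larger groups there. In the Homo sapiens assay, fluoro in place of hydrogen on an aromatic carbon gives only a 1.4-fold lower number from compound 2 to compound 4 (0.14 log units; within the scatter), so the fluorine does not account for the high number of compound 2, which the opening comparison could not settle. The same chain change leaves a physicochemical assay for acid dissociation, unresolved, with a number 0.10 log units lower from compound 3 to compound 4 (within the scatter); there compound 3 gives 8.6 and compound 4 gives 8.5.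

No measurement shown gives the reason that the ethyl chain and the larger groups differ in half-life. From the compounds shown here alone, it remains open whether the half-life would hold or change with a propyl chain or a chain ending in a hydroxyl group, and whether isobutyl would give the same low number in a compound with hydrogen in place of the fluorine.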